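Trimming the Biphenyl Arm of a T-type Channel Compound

A few compounds are considered here, and "the series" means these few. Any claim that something is new, unique, unknown or untested is made for them only; others in the source may bear on it.

Compound 1 `CN(C)CCCCCSC1=Nc2ccccc2C(CC(=O)NCc2ccccc2)N1c1ccc(-c2ccccc2)cc1` gives 85.6% in an assay on cells for inhibition of Voltage-dependent T-type calcium channel subunit alpha-1I (Homo sapiens), read by patch clamp, tested at 10 uM (a higher number here means more inhibition at the concentration tested (going by the name of the read-out), a lower number less inhibition), the higher of the two numbers recorded so far. Within the data shown here, its only measured neighbour, compound 2 `CN(C)CCCCCSC1=Nc2ccccc2C(CC(=O)NCc2ccc(F)cc2)N1c1ccc(-c2ccccc2)cc1`, carries a fluorine on the benzyl ring of the amide and gives 69.3% in this assay; that step is a number 16.3 percentage points lower from compound 1 to compound 2 (beyond the scatter). Compound 3 `CN(C)CCCCCSC1=Nc2ccccc2C(CC(=O)NCc2ccccc2)N1c1ccccc1` is still unmeasured. It differs from compound 1 by hydrogen in place of phenyl on an aromatic carbon, so the outer ring of the biphenyl group on the ring nitrogen of the shared core is gone. Among the measured compounds shown here, no measured step touches this part of the molecule, and the step of a number 16.3 percentage points lower from compound 1 to compound 2 (beyond the scatter) concerns a different ring, showing only that a small change costs a modest amount of inhibition. Removing a whole ring is a larger change, so a larger drop is expected. In this assay compound 3 is estimated at 55%, with a range from 25% to 80%. The expected step is a number 30.6 percentage points lower from compound 1 to compound 3 (beyond the scatter).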

Compound 3, a percentage reported as inhibition, at one concentration (the size of the read-out at that concentration, not a potency): 76%
Compound 3: the middle estimate sits 21 percentage points below what was measured; low and high end bracket the measured number.
By their numbers in this assay, from the lowest: compounds 2, 3 and 1 (each within the scatter of the next, the first and the last beyond it).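

In this assay, among these compounds, the step to the plain phenyl compound reads a number 9.6 percentage points lower from compound 1 to compound 3 (within the scatter) and so gives the first look at this position: the 4-phenylphenyl group can be cut back to phenyl, losing a whole six-membered aromatic ring, with no difference that this read-out can separate from ordinary scatter. At this single concentration, then, the outer ring is not required for inhibition, although a percentage of this kind is not a potency and cannot show whether a smaller difference in potency exists. Nothing available explains why the ring can be removed in this way. As far as these compounds go, it remains open what a methoxy group or a chlorine atom on this same aromatic carbon would do. A cyclohexyl group in place of the remaining phenyl on the ring nitrogen is also an open case.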